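This account rests on a few compounds, and the source may have more. Where it says the series, first, only, none or still open, it means among the compounds named here.

Compound 2 `COc1cc(N(Cc2nc3ccccc3[nH]2)S(=O)(=O)c2ccc(Br)cc2)cc(OC)c1OC` gives 6890 nM in a functional assay on PC-3 cells (Homo sapiens) for inhibition, read by MTT assay, with a stated time of 48 h (a lower number here means a stronger inhibitor, a higher number a weaker inhibitor), the highest of the two numbers in hand; compound 1 `COc1cc(N(Cc2nc3ccccc3[nH]2)S(=O)(=O)c2ccc(C)cc2)cc(OC)c1OC` gives 3340 nM, and the step of a 2.1-fold higher number from compound 1 to compound 2 (0.31 log units; beyond the scatter) covers a bromo in place of methyl on an aromatic carbon. Compound 3 `COc1cc(N(Cc2nc3ccccc3[nH]2)C(=O)c2ccccc2)cc(OC)c1OC` carries instead (benzoyl in place of (4-bromophenyl)sulfonyl on a nitrogen on an aromatic ring). Among the measured compounds shown here, no measured step touches this exchange; the only step known is the modest one from compound 1 to compound 2, so it offers no direction for the new amide. Compound 3 is therefore expected near compound 2, with a wide margin, the estimated step being a 1.5-fold lower number from compound 2 to compound 3 (0.19 log units; within the scatter). Compound 3 is estimated at 4500 nM, between 1200 nM and 17000 nM.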

Compound 3, half-maximal inhibitory concentration: > 50000 nM
Compound 3 ended at the assay's limit; the forecaster's own chance of this, stated with the estimate: 10%; at least 11-fold (1.04 log units) between middle value and limit.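

In this assay compound 3 gives > 50000 nM, which is a limit of the assay and not a number. On this nitrogen, the change to benzoyl gives an at least 7.2-fold higher number from compound 2 to compound 3 (0.86 log units; beyond the scatter) and an at least 14-fold higher number from compound 1 to compound 3 (1.17 log units; beyond the scatter). The group on the nitrogen therefore weighs more in this series than the methyl-to-bromo exchange on the sulfonyl-bearing aromatic ring, whose step was only modest.

How far compound 3 lies past its limit cannot be read. Also open, going by these compounds, is whether the loss follows the carbonyl itself or the whole benzoyl group, which an acetyl or a methanesulfonyl group on this nitrogen would help to separate.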